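The source may report more compounds than this note shows. Statements on the series, on what has been measured and on what is new or still open speak of the compounds shown alone.

In a functional assay on HL-60 cells (Homo sapiens) for inhibition, read by CCK-8 assay, with a stated time of 48 h, tested at 20 uM (on this read-out lower numbers stand for less inhibition of growth and higher numbers for more inhibition of growth at the one concentration tested), compound 1 (`Cc1ccc(S(=O)(=O)Oc2ccccc2/C=C(\C#N)C(=O)Nc2nnc(C)s2)cc1`) gives 78%. Two further compounds were measured in the same way: compound 2 (`Cc1ccc(S(=O)(=O)Oc2cccc(/C=C(\C#N)C(=O)Nc3nnc(C)s3)c2)cc1`) gives 71%, and compound 3 (`CC(=O)Nc1ccc(S(=O)(=O)Oc2cccc(/C=C(\C#N)C(=O)Nc3nnc(-c4cccs4)s3)c2)cc1`) gives 71%. Compound 1 therefore stands level with both, as its gap to each lies within the usual scatter of repeated measurements.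

The next compound to be examined is compound 4 (`COc1ccc(Cc2nnc(NC(=O)/C(C#N)=C/c3ccccc3OS(=O)(=O)c3ccc(C)cc3)s2)cc1`), and it departs from compound 1 in one place: 4-methoxyphenyl in place of hydrogen on a saturated chain carbon bound to an aromatic carbon. In words, 4-methoxyphenyl stands in place of hydrogen on a saturated chain carbon bound to an aromatic carbon, so that methyl becomes 4-methoxybenzyl.

Within the data shown here, no pair of measured compounds differs in one place only, so no measured step shows what a change of this kind does in this assay. The three values offer only a general guide: they sit close together, and none of them marks a compound with little effect on growth. The expectation is therefore a small downward step or none beyond the scatter, held with wide uncertainty. The expected result is a number 8 percentage points lower from compound 1 to compound 4 (within the scatter). For compound 4 the estimated value is 70%, with an expected range from 48% to 88%.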

Compound 4, percent growth inhibition at one concentration: 25%
For compound 4 the middle estimate is 45 percentage points above the measured one, outside the stated range (below it).
By their numbers in this assay, from the lowest: compound 4; then compounds 2, 3 and 1 (each within the scatter of the next).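

The step at this position is large: in this assay, exchanging methyl for 4-methoxybenzyl, with 4-methoxyphenyl in place of hydrogen on a saturated chain carbon bound to an aromatic carbon, gives a number 53 percentage points lower from compound 1 to compound 4 (beyond the scatter). Among these compounds, this is the first single change measured, and it shows that growth inhibition on the core of compound 1 depends strongly on what stands at this place, which the earlier compounds, none of them differing from another in one place only, could not show. The data offer no measurement that accounts for this loss.

The compounds shown leave open which part of the 4-methoxybenzyl group goes with the loss, since a plain benzyl group, an ethyl group or a longer alkyl chain at this place could either hold near compound 1 or fall towards compound 4. Going by these compounds, it also remains open whether the same exchange would have a comparable effect on a core other than that of compound 1, or whether an amine or a carboxylic acid on the benzyl ring in place of methoxy would restore any of the inhibition.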